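Swapping the basic amine on the acrylamide chain

The source may report more compounds than this note shows. Statements on the series, on what has been measured and on what is new or still open speak of the compounds shown alone.

The study follows a series built on one shared core. Compound 1 `CC(C)/C=C/C(=O)Nc1cc2c(N3CCc4ccccc43)ncnc2cc1O[C@@H]1CCOC1` carries an isopropyl group on the double-bonded chain carbon of its acrylamide; in a functional assay on PC-3 cells (Homo sapiens) for antiproliferative activity, read by MTT assay, with a stated time of 72 h (a higher number here means a weaker inhibitor, a lower number a stronger inhibitor), compound 1 gives 11200 nM. For the measured compounds named here, compound 2 `CN1CCN(C/C=C/C(=O)Nc2cc3c(N4CCc5ccccc54)ncnc3cc2O[C@@H]2CCOC2)CC1` places a (4-methylpiperazin-1-yl)methyl group there instead, and in this assay compound 2 gives 4210 nM, the lowest of the two numbers so far; the step of a 2.7-fold lower number from compound 1 to compound 2 (0.42 log units; beyond the scatter) lies beyond the scatter but is modest.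

Compound 3 `O=C(/C=C/CN1CCC(CO)CC1)Nc1cc2c(N3CCc4ccccc43)ncnc2cc1O[C@@H]1CCOC1` is the next member: 4-(hydroxymethyl)piperidin-1-yl in place of 4-methylpiperazin-1-yl on a saturated chain carbon bound to a double-bonded chain carbon. Going by the values given here, no measured step covers this particular exchange of one saturated amine ring for another; the only measured step, from compound 1 to compound 2, concerns the introduction of the whole amine-bearing chain rather than a change within it, and was itself modest. On that basis the step of a 1.1-fold lower number from compound 2 to compound 3 (0.02 log units; within the scatter) is expected to be small, with no clear direction beyond the scatter. Compound 3 is therefore estimated to give about 4000 nM in this assay, within a range of 1500 nM to 11000 nM.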

Compound 3, half-maximal inhibitory concentration: 3310 nM
Compound 3: the middle estimate sits 1.2-fold (0.08 log units) above what was measured, and the stated range covers the measured number.
By their numbers in this assay, from the lowest: compounds 3 and 2 (each within the scatter of the next); then compound 1.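

The exchange of 4-methylpiperazin-1-yl for 4-(hydroxymethyl)piperidin-1-yl on the saturated chain carbon gives a 1.3-fold lower number from compound 2 to compound 3 (0.10 log units; within the scatter) in this assay, so the two compounds cannot be told apart here, even though the ring nitrogen that leaves is replaced by a ring carbon carrying hydroxymethyl, with one hydrogen-bond donor entering. With a 3.4-fold lower number from compound 1 to compound 3 (0.53 log units; beyond the scatter) as a second step beyond the scatter, the separation from the isopropyl compound now holds for two different ring amines on this chain rather than for compound 2 alone, and both steps remain modest. Nothing measured here explains either step or the lack of separation between the two ring amines.

The compounds shown leave open whether the hydroxymethyl group contributes anything of its own, which a plain piperidin-1-yl ring at the same place would help to settle. They also leave open whether a morpholin-4-yl ring or an open-chain dimethylamino group on that saturated chain carbon would fall with compound 2 and compound 3 in this assay or nearer to compound 1.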